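Notes on the methoxy-to-hydrogen step in the series

This account rests on a few compounds, and the source may have more. Where it says the series, first, only, none or still open, it means among the compounds named here.

Within the data shown here, compound 2 `COc1ccc(C(=O)OC2(C(=O)Nc3ccc([N+](=O)[O-])cc3)CCCCC2)cc1` gives the lowest of the three numbers so far in a functional assay on HepG2 cells (Homo sapiens) for inhibition, read by MTT assay, with a stated time of 72 h (on this read-out lower numbers stand for stronger inhibition and higher numbers for weaker inhibition), at 57.1 nM. Compound 1 `Cc1ccc(C(=O)OC2(C(=O)Nc3ccc([N+](=O)[O-])cc3)CCCCC2)cc1` stands nearest, with 61.2 nM in this assay; the step of a 1.1-fold lower number from compound 1 to compound 2 (0.03 log units; within the scatter) lies within the scatter, so the two cannot be ordered. Among the measured compounds shown here, compound 3 `CCOC(=O)c1ccccc1C(=O)OC1(C(=O)Nc2ccc([N+](=O)[O-])cc2)CCCCC1` is furthest, with 517 nM in this assay; no single step links compound 3 to compound 2, so the two values stand only as they are.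

Compound 4 `O=C(OC1(C(=O)Nc2ccc([N+](=O)[O-])cc2)CCCCC1)c1ccccc1` is not yet measured. From compound 2 it differs by hydrogen in place of methoxy on an aromatic carbon; read one bond further out, 4-methoxyphenyl becomes phenyl. For the measured compounds named here, the only measured step that touches the same aromatic carbon is a 1.1-fold lower number from compound 1 to compound 2 (0.03 log units; within the scatter), within the scatter: two different groups on that carbon, para to a large group, gave numbers that cannot be told apart. Whether a bare hydrogen there behaves the same is not shown by any measured pair. For compound 4 the expected step in this assay is therefore a 1.3-fold higher number from compound 2 to compound 4 (0.12 log units; within the scatter), a change not beyond the scatter, if anything toward a slightly higher number. Compound 4 is expected at 75 nM in this assay, within 35 nM to 160 nM.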

Compound 4, half-maximal inhibitory concentration: 734 nM
The estimate for compound 4 lay 9.8-fold (0.99 log units) below the measured number, and the stated range ends below it.
By their numbers in this assay, from the lowest: compounds 2 and 1 (each within the scatter of the next); then compounds 3 and 4 (each within the scatter of the next).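

In this assay, this aromatic carbon, para to a large group, proves far more sensitive than the methyl-to-methoxy step suggested: a 13-fold higher number from compound 2 to compound 4 (1.11 log units; beyond the scatter) and a 12-fold higher number from compound 1 to compound 4 (1.08 log units; beyond the scatter) are both large, so hydrogen is clearly separated from the two groups that could not be told apart from each other. Having a group on the ring is not enough to give the low numbers, since compound 3 goes against that reading: a 1.4-fold higher number from compound 3 to compound 4 (0.15 log units; within the scatter) lies within the scatter, although its ethoxycarbonyl sits on a different aromatic carbon from the methoxy of compound 2, so this step says nothing direct about the position under study. Nothing available explains the large step from methoxy or methyl to hydrogen.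

Going by these compounds, it remains open whether a hydroxy group, an amine or a carboxylic acid on this carbon would stay with compound 1 and compound 2 or fall with compound 4. Also open, on these data alone, is whether a longer chain, such as butoxy, would keep the number of compound 2 in this assay.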